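The source may report more compounds than this note shows. Statements on the series, on what has been measured and on what is new or still open speak of the compounds shown alone.

Measured compounds:
- compound 1, `CCCCCCCCC#Cc1cn(C/C=C\CN2C(=O)c3ccccc3C2=O)c(=O)[nH]c1=O`, in a functional assay on L1210 cells (Mus musculus) for antiproliferative activity, read by MTT assay, with a stated time of 2 days (on this read-out lower numbers stand for stronger inhibition and higher numbers for weaker inhibition), compound 1 gives 45000 nM
- compound 2, `CCCCCCC#Cc1cn(C/C=C/CN2C(=O)c3ccccc3C2=O)c(=O)[nH]c1=O`, compound 2 gives 43000 nM
- compound 3, `O=C1c2ccccc2C(=O)N1C/C=C/Cn1cc(C#CCCc2ccccc2)c(=O)[nH]c1=O`, compound 3 gives 44000 nM

Compound 1 has the highest of the three numbers, but its nearest neighbour compound 3 and its furthest neighbour compound 2 both sit within the usual scatter of it, so the three compounds cannot be told apart on these values.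

The new compound is compound 4, `Cc1ccc(C#Cc2cn(C/C=C\CN3C(=O)c4ccccc4C3=O)c(=O)[nH]c2=O)cc1`. Compared with compound 1 it carries 4-methylphenyl in place of octyl on a triple-bonded carbon. Among the measured compounds shown here, the only measured step that resembles this exchange of a chain for an aromatic ring is a 1.0-fold higher number from compound 2 to compound 3 (0.01 log units; within the scatter), where a phenyl replaced a butyl on a saturated chain carbon and the number stayed put. In compound 4 the aromatic ring is attached directly to the triple-bonded carbon rather than two bonds further along, so the precedent is only partial, but nothing in the measured set points to a shift in either direction.

The expected step is therefore no change at the digits printed from compound 1 to compound 4 (within the scatter), no more than the scatter. Compound 4 is estimated at 45000 nM, with a likely range from 15000 nM to 130000 nM.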

Compound 4, half-maximal inhibitory concentration: 245000 nM
Estimate against measurement, compound 4: 5.4-fold (0.74 log units) below; measured number outside the range, above it.
By their numbers in this assay, from the lowest: compounds 2, 3 and 1 (each within the scatter of the next); then compound 4.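

In this assay the group on the triple-bonded carbon turns out to matter, since 4-methylphenyl in place of octyl gives a 5.4-fold higher number from compound 1 to compound 4 (0.74 log units; beyond the scatter) and so weaker inhibition. The earlier step, a 1.0-fold higher number from compound 2 to compound 3 (0.01 log units; within the scatter), had suggested that a chain could give way to an aromatic ring at no cost, but there the ring sat two bonds along the chain from the triple-bonded carbon, whereas here it sits on that carbon itself; the two steps start from different compounds, so this contrast holds only for these pairs. Nothing measured here explains the rise in the number.

The compounds shown do not separate the effect of the aromatic ring from that of its methyl group, so a plain phenyl on the triple-bonded carbon would be the direct test. A cyclohexyl in the same place would ask whether any ring gives this result or only a flat aromatic one, and a 4-aminophenyl would show how far the outcome depends on what the ring carries.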